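Changing the Nitrogen Group on an Inactive Compound

The compounds below may be only part of what the source reports. "The series", "measured", "known", "first", "only" and "open" are said of these compounds alone.

Compound 1 `C=CCN1C(=O)C(=O)c2cc(-c3ccc(OC)cc3)ccc21` carries an allyl group on an amide-type nitrogen in a ring. In a functional assay on K562 cells (Homo sapiens) for antiproliferative activity, read by MTT assay, with a stated time of 48 h (a lower number here means a stronger inhibitor, a higher number a weaker inhibitor), compound 1 gives 390 nM. Compound 2 `COc1ccc(-c2ccc3c(c2)C(=O)C(=O)N3c2ccc(OC)cc2)cc1` shares the core of compound 1 but has 4-methoxyphenyl on that nitrogen. In this assay compound 2 gives > 10000 nM, which is a limit of the assay and not a number.

Compound 3 `COc1ccc(-c2ccc3c(c2)C(=O)C(=O)N3Cc2cccc(Cl)c2)cc1` keeps the same core and places 3-chlorobenzyl in place of 4-methoxyphenyl on that nitrogen (3-chlorobenzyl in place of 4-methoxyphenyl on an amide-type nitrogen in a ring). For the measured compounds named here, only one measured step bears on this change: the swap of allyl for 4-methoxyphenyl gave an at least 25-fold higher number from compound 1 to compound 2 (1.40 log units; beyond the scatter), a large step beyond the scatter. Going by the values given here, that single step shows that the group on this nitrogen can shift the number strongly, although no measured compound carries a benzyl group. Since 4-methoxyphenyl leaves, a large step toward lower numbers is expected, returning to the neighbourhood of compound 1. The expected change is an at least 25-fold lower number from compound 2 to compound 3 (1.39 log units; beyond the scatter). For compound 3 the estimated value is 400 nM, with an expected range of 60 nM to 3000 nM.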

Compound 3, half-maximal inhibitory concentration: 200 nM
For compound 3 the middle estimate is 2.0-fold (0.30 log units) above the measured one; the range from low to high includes it.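

In this assay, 3-chlorobenzyl in place of 4-methoxyphenyl on the amide-type nitrogen gives an at least 50-fold lower number from compound 2 to compound 3 (1.69 log units; beyond the scatter). The group that leaves and the group that enters have the same count of heavy atoms and each holds one six-membered aromatic ring of carbon only, so those shared features alone do not produce the weak result; an aromatic ring on this nitrogen can go with a strong number. The comparison with the allyl compound gives a 2.0-fold lower number from compound 1 to compound 3 (0.29 log units; within the scatter), which lies within the scatter, so this position accepts two quite different groups without a readable difference between them, while the value of compound 2 is a limit and not a number: the limit of > 10000 nM in this assay, at which 1 of the 3 values shown sits.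

The swap changes several things at once, since 3-chlorobenzyl brings both a saturated carbon on the nitrogen and a chlorine, while 4-methoxyphenyl brings a methoxy group and no such carbon. Plain benzyl, 4-methoxybenzyl and 3-chlorophenyl on this nitrogen would be needed to separate those parts, and a longer chain or one ending in an amine remains an open question at the same place.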